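The source may hold more compounds than are shown below. What is called first, only, known or untested is meant among the compounds shown, and "the series" means these compounds.

Measured so far:
Compound 1 `O=[N+]([O-])c1ccc(COc2ccc(Nc3ncnc4cc5c(cc34)OCCOCCO5)cc2)cc1` gives > 100000 nM, which is a limit of the assay and not a number.
Compound 2 `c1ccc(COc2ccc(Nc3ncnc4cc5c(cc34)OCCOCCO5)cc2)cc1` gives 55500 nM.
Compound 3 `O=[N+]([O-])c1ccc(COc2ccc(Nc3ncnc4cc5c(cc34)OCCOCCOCCOCCO5)cc2)cc1` gives > 100000 nM, again a limit of the assay and not a number.

All three were tested in a functional assay on HepG2 cells (Homo sapiens) for antiproliferative activity, read by MTT assay, with a stated time of 72 h; on this read-out higher numbers stand for weaker inhibition and lower numbers for stronger inhibition. Compound 1 and compound 2 share one core and differ in a single place: hydrogen in place of nitro on an aromatic carbon. This change gave an at least 1.8-fold lower number from compound 1 to compound 2 (0.25 log units; that floor lies within the scatter), a step whose floor lies within the scatter, so its true size is not fixed, because of the limit of > 100000 nM in this assay, at which 2 of the 3 values shown sit. Compound 3 carries a different core, and the difference between the two cores is not broken down here.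

Compound 4 `c1ccc(COc2ccc(Nc3ncnc4cc5c(cc34)OCCOCCOCCOCCO5)cc2)cc1` has not yet been measured. It stands to compound 3 as compound 2 stands to compound 1: hydrogen in place of nitro on an aromatic carbon, the same change at the same kind of place. From compound 3 to compound 4 the expected step in this assay is therefore an at least 1.6-fold lower number from compound 3 to compound 4 (0.22 log units; that floor lies within the scatter), resting on compound 1 and compound 2 with an at least 1.8-fold lower number from compound 1 to compound 2 (0.25 log units; that floor lies within the scatter) and on compound 3 with > 100000 nM. Compound 4 is expected to give about 60000 nM, most likely between 25000 nM and 150000 nM.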

Compound 4, half-maximal inhibitory concentration: 11900 nM
Compound 4: middle estimate off by 5.0-fold (0.70 log units), on the high side, outside the stated range (below it).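

On the second core, hydrogen in place of nitro in this assay gave an at least 8.4-fold lower number from compound 3 to compound 4 (0.92 log units; beyond the scatter), a step that clears the usual scatter of the measurements. Both cores therefore point the same way, but only the second gives a step that is firm on its own, and two cores are too few for a general rule about this series. How far the two steps really differ in size stays unknown: the same change on two cores in this assay, an at least 1.8-fold lower number (0.25 log units; that floor lies within the scatter) from compound 1 to compound 2 and an at least 8.4-fold lower number (0.92 log units; beyond the scatter) from compound 3 to compound 4; the limit leaves it open whether they differ The true size of each step is also unfixed, because each rests on a nitro compound that reaches no actual number: the limit of > 100000 nM in this assay, at which 2 of the 4 values shown sit.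

The compounds shown leave open how other groups in the same place on the benzyl ring, such as an amine, a carboxylic acid or a methoxy group, would read in this assay. Among the compounds shown here, they also leave open how much lower the number can go, since even the hydrogen compounds were tested with only this one change on these two cores.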